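Amide to urea on the anilide side of the series

The compounds below may be only part of what the source reports. "The series", "measured", "known", "first", "only" and "open" are said of these compounds alone.

Of the compounds shown here, two of the shared core have been measured in a functional assay on SR cells (Homo sapiens) for inhibition, read by sulforhodamine B assay, with a stated time of 48 h; on this read-out lower numbers stand for stronger inhibition of growth and higher numbers for weaker inhibition of growth. Compound 1 `COc1cc(-c2nn(-c3cccc(NC(=O)c4cccc(C(F)(F)F)c4)c3)cc2-c2ccncc2)ccc1Cl` gives 4590 nM; compound 2 `O=C(Nc1cccc(-n2cc(-c3ccncc3)c(-c3ccc(Cl)c(O)c3)n2)c1)Nc1cc(C(F)(F)F)cc(C(F)(F)F)c1` gives 3660 nM, and the two numbers lie within the scatter of each other, so no order can be set between them. Compound 3 `COc1cc(-c2nn(-c3cccc(NC(=O)Nc4ccc(Cl)c(C(F)(F)F)c4)c3)cc2-c2ccncc2)ccc1Cl` is not yet measured. It differs from compound 1 by (4-chloro-3-(trifluoromethyl)phenyl)amino in place of 3-(trifluoromethyl)phenyl on a carbonyl carbon. Among the compounds with values here, no measured pair isolates this change; compound 2 already carries a urea and its value differs from compound 1 by less than the scatter, so the step of a 1.4-fold lower number from compound 1 to compound 3 (0.16 log units; within the scatter) is expected to be small, if any. Compound 3 is estimated at 3200 nM, within 1100 nM to 9500 nM.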

Compound 3, concentration for total growth inhibition: 2480 nM
For compound 3 the middle estimate is 1.3-fold (0.11 log units) above the measured one, and the stated range covers the measured number.
By their numbers in this assay, from the lowest: compounds 3, 2 and 1 (each within the scatter of the next).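

In this assay, the first pair differing in one place gives a 1.9-fold lower number from compound 1 to compound 3 (0.27 log units; within the scatter), so (4-chloro-3-(trifluoromethyl)phenyl)amino is tolerated in place of 3-(trifluoromethyl)phenyl on this carbonyl carbon, with no step beyond the scatter. No supporting data bear on this step.

The amino link and the chlorine enter together, so their separate contributions cannot be read from this pair. Also open, going by these compounds, is how a morpholine or a carboxylic acid on the terminal ring would read in this assay.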